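This account rests on a few compounds, and the source may have more. Where it says the series, first, only, none or still open, it means among the compounds named here.

Measured so far, in a physicochemical assay for acid dissociation:
- compound 2, `C=CCN(C1=NCCN1)c1c(Br)cccc1Br`: 10.7
- compound 3, `CC(C)=CCN(C1=NCCN1)c1c(Br)cccc1Br`: 10.8
- compound 1, `Brc1cccc(N(CC2CC2)C2=NCCN2)c1Br`: 11.1

Compound 2 holds the lowest number of the three, although compound 3 sits within the scatter of it; compound 1 lies beyond the scatter above compound 2. Compound 4, `Brc1cccc(Br)c1N(C1=NCCN1)C1CCCCC1`, is not yet measured. It differs from compound 2 in one place: cyclohexyl in place of allyl on a nitrogen on an aromatic ring. Among the compounds with values here, the only measured step of the same kind, a number 0.10 log units higher from compound 2 to compound 3 (within the scatter), trades one unsaturated chain for another and says little about a saturated ring. Compound 1, whose chain has no double bond, gives a higher number than compound 2. A modest rise, a number 0.30 log units higher from compound 2 to compound 4 (within the scatter), is therefore expected. Compound 4 is estimated at 11, between 10.6 and 11.4.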

Compound 4, acid dissociation constant: 11.3
Beside the measured number, compound 4's estimate is 0.30 log units below it; the measured number falls inside the stated range.
By their numbers in this assay, from the lowest: compounds 2, 3, 1 and 4 (each within the scatter of the next, the first and the last beyond it).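

In this assay the group on the nitrogen on an aromatic ring can clearly move the number: cyclohexyl in place of allyl gives a number 0.60 log units higher from compound 2 to compound 4 (beyond the scatter) and cyclohexyl in place of 3-methylbut-2-en-1-yl gives a number 0.50 log units higher from compound 3 to compound 4 (beyond the scatter) as well. Within the data shown here, the earlier swap of one unsaturated chain for the other stayed within the scatter, so this is the first change at this position that goes beyond it. No supporting measurement accounts for the rise.

This change removes a double bond and adds a ring together, and the two cannot be separated here. Going by these compounds, whether an open hexyl chain or a smaller cyclopentyl ring at this position would give a similar number remains open.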